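The compounds below may be only part of what the source reports. "The series", "measured", "known", "first", "only" and "open" are said of these compounds alone.

Working notes on the series.

Two analogues of the shared core have been measured in a functional assay on LNCaP cells (Homo sapiens) for cytotoxicity, read by MTT assay, with a stated time of 72 h; a lower number here means a stronger inhibitor, a higher number a weaker inhibitor. Compound 1 `COc1cc(/C(=C\c2cn(C(C)=O)c3ccc(OCc4ccccc4)cc23)C(=O)O)cc(OC)c1OC` gives 59600 nM in this assay. Compound 2 `COc1ccccc1/C(=C\c1cn(C(C)=O)c2ccc(OCc3ccccc3)cc12)C(=O)O` gives 48500 nM in this assay. Between them, the number moved a 1.2-fold lower number from compound 1 to compound 2 (0.09 log units; within the scatter), a step that does not separate the two compounds. Among the compounds with values here, compound 2 thus holds the lowest of the two numbers seen so far, but its only neighbour, compound 1, sits within the scatter of it, so no order between the two can be claimed.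

Compound 3 `CC(=O)n1cc(/C=C(/C(=O)O)c2ccc(Cl)cc2)c2cc(OCc3ccccc3)ccc21` is the next step and remains to be measured in this assay. Relative to compound 2 it differs as follows: 4-chlorophenyl in place of 2-methoxyphenyl on a double-bonded chain carbon bound to a carbonyl carbon and a double-bonded chain carbon. Within the data shown here, the one measured step that bears on a change at this place is the move from compound 1 to compound 2, which stayed within the scatter. On that basis a step in this assay of no more than the scatter is expected from compound 2 to compound 3, in either direction, a 1.2-fold lower number from compound 2 to compound 3 (0.06 log units; within the scatter) being the estimate. Compound 3 is accordingly expected to give about 42000 nM in this assay, with a range from 15000 nM to 110000 nM.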

Compound 3, half-maximal inhibitory concentration: > 100000 nM
Compound 3 ended at the assay's limit; the forecaster's own chance of this, stated with the estimate: 15%; middle value at least 2.3-fold (0.37 log units) from the limit.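

In this assay compound 3 stands at a limit of the assay, which is not a number: the limit of > 100000 nM in this assay, at which 1 of the 3 values shown sits.

Even so, this place on a double-bonded chain carbon bound to a carbonyl carbon and a double-bonded chain carbon is now seen to respond to the aryl group it carries: 4-chlorophenyl in place of 2-methoxyphenyl gives an at least 2.0-fold higher number from compound 2 to compound 3 (0.31 log units; beyond the scatter), the first step in the series beyond the scatter, whereas the earlier change gave only a 1.2-fold lower number from compound 1 to compound 2 (0.09 log units; within the scatter). Going by these compounds, the comparison with the trimethoxy analogue, an at least 1.6-fold higher number from compound 1 to compound 3 (0.22 log units; that floor lies within the scatter), is a floor that does not separate the two compounds, and the full size of both steps involving compound 3 remains unknown.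

The two aryl changes alter the ring's substituent and where it sits together, so the compounds shown cannot say whether the step follows from losing the methoxy group, gaining the chlorine, or the substitution site; a plain phenyl and a 4-methoxyphenyl at this place would separate these readings. Also open, on these data alone, is whether any group here, such as an aminophenyl, can bring the number well below those of compound 1 and compound 2.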